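From methyl to 2-hydroxyethyl on compound 2

The source may hold more compounds than are shown below. What is called first, only, known or untested is meant among the compounds shown, and "the series" means these compounds.

Measured so far in a functional assay for inhibition, read by fluorescence and spectrophotometry, with a stated time of 30 h (on this read-out lower numbers stand for stronger inhibition and higher numbers for weaker inhibition), for this series
- compound 1 `COc1ccc(-c2cc(=O)c3ccc(O)cc3o2)cc1OC` gives 47400 nM as its value
- compound 2 `COc1ccc(-c2cc(=O)c3ccc(OCCCN4CCC(C)CC4)cc3o2)cc1` gives 42600 nM as its value

Compound 2 at 42600 nM stands level with compound 1, the two numbers lying within the usual scatter of each other. Compound 3 `COc1ccc(-c2cc(=O)c3ccc(OCCCN4CCC(CCO)CC4)cc3o2)cc1` has not yet been measured. It differs from compound 2 by hydroxymethyl in place of hydrogen on a saturated chain carbon bound to a saturated ring carbon as a single change, hydroxymethyl in place of hydrogen on a saturated chain carbon bound to a saturated ring carbon, so that methyl becomes 2-hydroxyethyl. Within the data shown here, no two measured compounds differ in one place, so the series offers no measured step as a guide. No direction can be argued, and no step beyond the scatter is expected in this assay here. The estimated change is a 1.1-fold lower number from compound 2 to compound 3 (0.03 log units; within the scatter) and stays within the scatter. For compound 3 the estimated value is 40000 nM with an expected range from 17000 nM to 90000 nM as the likely span.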

Compound 3, half-maximal inhibitory concentration: 43200 nM
Estimate against measurement, compound 3: 1.1-fold (0.03 log units) below; the measured number falls inside the stated range.
By their numbers in this assay, from the lowest: compounds 2, 3 and 1 (each within the scatter of the next).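

In this assay, among these compounds, the change from methyl to 2-hydroxyethyl gives a 1.0-fold higher number from compound 2 to compound 3 (0.01 log units; within the scatter) and supplies the only comparison between compounds that differ in one place. The earlier compounds shown here offered no such reading; here, hydroxymethyl in place of hydrogen on a saturated chain carbon bound to a saturated ring carbon, with its 2 heavy atoms, 1 hydrogen-bond donor and 1 hydrogen-bond acceptor, leaves compound 3 within the scatter of compound 2. No supporting measurement bears on this result, so no explanation can be offered.

On these data alone, whether an amine, a carboxylic acid or a longer chain in place of the 2-hydroxyethyl group would give a step beyond the scatter remains open. A single step at this position also says nothing about changes elsewhere on the shared core.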